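Replacing the Ether Tail of Compound 1 with a Sulfonamide

The source may report more compounds than this note shows. Statements on the series, on what has been measured and on what is new or still open speak of the compounds shown alone.

Compound 1 `c1cc([C@H]2CC[C@]3(CC2)OOC2(O3)C3CC4CC(C3)CC2C4)ccc1OCCCNC1CCOCC1` carries a 3-((oxan-4-yl)amino)propoxy group on its core. Within the data shown here, in an ADME assay on microsomes from liver (Homo sapiens) for metabolic stability, read by LC-MS, tested at 1 uM (a lower number here means slower removal, a higher number faster removal of the compound), compound 1 gives 10 mL.min-1.g-1, the lower of the two plain numbers measured so far. Compound 2 `CC1(C)CC(O)(COc2ccc([C@H]3CC[C@]4(CC3)OOC3(O4)C4CC5CC(C4)CC3C5)cc2)CC(C)(C)N1` gives 14 mL.min-1.g-1 in this assay, a step of a 1.4-fold higher number from compound 1 to compound 2 (0.15 log units; within the scatter). Compound 3 `N[C@H]1CC[C@H](Oc2ccc([C@H]3CC[C@]4(CC3)OOC3(O4)C4CC5CC(C4)CC3C5)cc2)CC1` is reported in this assay only as a limit, < 7 mL.min-1.g-1; this is the limit of < 7 mL.min-1.g-1 in this assay, at which 1 of the 3 values shown sits. Against compound 3 the steps are an at least 1.4-fold lower number from compound 1 to compound 3 (0.15 log units; that floor lies within the scatter) and an at least 2.0-fold lower number from compound 2 to compound 3 (0.30 log units; that floor lies within the scatter), both floors that stay within the scatter.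

Compound 4 `NC1CCN(S(=O)(=O)c2ccc([C@H]3CC[C@]4(CC3)OOC3(O4)C4CC5CC(C4)CC3C5)cc2)CC1` differs from compound 1 in one place: (4-aminopiperidin-1-yl)sulfonyl in place of 3-((oxan-4-yl)amino)propoxy on an aromatic carbon. The two steps that replace the same tail of compound 1, a 1.4-fold higher number from compound 1 to compound 2 (0.15 log units; within the scatter) and an at least 1.4-fold lower number from compound 1 to compound 3 (0.15 log units; that floor lies within the scatter), both stay within the scatter, so no step beyond the scatter is expected in either direction. The step from compound 1 to compound 4 is therefore expected to be a 1.1-fold lower number from compound 1 to compound 4 (0.05 log units; within the scatter). Compound 4 is expected to give about 9 mL.min-1.g-1 in this assay, within a range from 5 mL.min-1.g-1 to 18 mL.min-1.g-1.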

Compound 4, intrinsic clearance in microsomes: < 7 mL.min-1.g-1
Compound 4 was reported as a limit; the forecaster's own chance of this, stated with the estimate: 30%; at least 1.2-fold (0.10 log units) between middle value and limit.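

In this assay compound 4 is reported only as a limit, < 7 mL.min-1.g-1. Among these compounds, all the earlier compounds join their tail to the aromatic ring through an oxygen, so compound 4 is the first to show this aromatic carbon, para to a large group, carrying a sulfonyl link instead, and the result stays low: an at least 1.4-fold lower number from compound 1 to compound 4 (0.15 log units; that floor lies within the scatter), so no real change from the ether tail can be claimed. Compound 3 and compound 4 sit at the same limit, so the step between them cannot be read: the limit of < 7 mL.min-1.g-1 in this assay, at which 2 of the 4 values shown sit.

As far as these compounds go, how far compound 4 lies under its limit stays unknown, and so does the separate share of the sulfonyl link and of the 4-aminopiperidin-1-yl ring, which entered together. A carbonyl link to the same ring, or a carboxylic acid on that ring in place of the amine, would begin to separate these questions.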